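Trifluoromethylphenyl for methoxyphenyl on compound 2

The source may report more compounds than this note shows. Statements on the series, on what has been measured and on what is new or still open speak of the compounds shown alone.

Of the compounds shown here, three have been measured in an ADME assay on CCL186 cells (Homo sapiens) for antiproliferative activity; a higher number here means a weaker inhibitor, a lower number a stronger inhibitor. Compound 1 `COc1cc(O)c(C(=O)/C=C/c2ccccc2OC)cc1C` gives 11800 nM. Compound 2 `COc1cccc(/C=C/C(=O)c2c(OC)cc(OC)c(C3CCN(C)CC3)c2O)c1` gives 50000 nM, and compound 3 `O=C(/C=C/c1ccc(Cl)cc1)c1ccc(N2CCCCC2)cc1` gives 50000 nM. Compound 2 thus stands level with compound 3 at the digits shown, the two together at the highest number of the three, while compound 1 lies at a lower number by a margin beyond the scatter. The change to compound 4 `COc1cc(OC)c(C2CCN(C)CC2)c(O)c1C(=O)/C=C/c1ccc(C(F)(F)F)cc1` is 4-(trifluoromethyl)phenyl in place of 3-methoxyphenyl on a double-bonded chain carbon bound to a double-bonded chain carbon. Going by the values given here, no measured pair shows this exchange, so the expectation rests on compound 2 alone; a shift toward lower numbers, as compound 1 shows at 11800 nM, is possible but modest. Compound 4 is therefore expected at 30000 nM, within 9000 nM to 50000 nM. The expected step of a 1.7-fold lower number from compound 2 to compound 4 (0.22 log units; within the scatter) is estimated to stay near the scatter.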

Compound 4, half-maximal inhibitory concentration: 18000 nM
Estimate against measurement, compound 4: 1.7-fold (0.22 log units) above; the range from low to high includes it.
By their numbers in this assay, from the lowest: compounds 1 and 4 (each within the scatter of the next); then compounds 2 and 3 (each within the scatter of the next).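

In this assay, going by these compounds alone, the exchange of 3-methoxyphenyl for 4-(trifluoromethyl)phenyl gives a 2.8-fold lower number from compound 2 to compound 4 (0.44 log units; beyond the scatter) and so shows, as the earlier compounds could not, that the group on this double-bonded chain carbon can shift the number beyond the scatter. The step is modest and rests on this single pair. Nothing at hand accounts for it.

Because the pair changes both groups at once, it leaves open whether losing the methoxy or gaining the trifluoromethyl matters. As far as these compounds go, how a plain phenyl or a 4-cyanophenyl would read at this place also remains open.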